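A few compounds are considered here, and "the series" means these few. Any claim that something is new, unique, unknown or untested is made for them only; others in the source may bear on it.

Compound 2 `CCOC(=O)OCOC(=O)C1=C(S[C@@H]2CN[C@H](C(=O)Nc3cccc(C(=O)O)c3)C2)[C@H](C)[C@@H]2[C@@H]([C@@H](C)O)C(=O)N12` gives 10% in an ADME assay on a cell-free system (plasma, Homo sapiens) for metabolic stability, read by LC-MS, with a stated time of 60 min, at 37 degrees C, tested at 50 uM (a higher number here means that more of the compound is left, a lower number that less of the compound is left), the lower of the two numbers seen, while compound 1 `C[C@@H](O)[C@H]1C(=O)N2C(C(=O)OCOC(=O)OC3CCCCC3)=C(S[C@@H]3CN[C@H](C(=O)Nc4cccc(C(=O)O)c4)C3)[C@H](C)[C@H]12` gives 46%. Within the data shown here, the one measured step that bears on what follows is a number 36 percentage points lower from compound 1 to compound 2 (beyond the scatter). Compound 3 `COC(=O)OCOC(=O)C1=C(S[C@@H]2CN[C@H](C(=O)Nc3cccc(C(=O)O)c3)C2)[C@H](C)[C@@H]2[C@@H]([C@@H](C)O)C(=O)N12` differs from compound 2 in one place: hydrogen in place of methyl on a saturated chain carbon bound to an oxygen next to a carbonyl group. This is a change of the same kind as the measured one, only smaller, so a further fall in this assay is expected, modest and probably within the scatter, given a number 36 percentage points lower from compound 1 to compound 2 (beyond the scatter) and how little of compound 2 already remains. For compound 3 the expected value is 6%, ranging from 1% to 14%. That means an expected step of a number 4 percentage points lower from compound 2 to compound 3 (within the scatter).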

Compound 3, percent of the compound remaining: 33%
Compound 3: the middle estimate sits 27 percentage points below what was measured, and the stated range ends below it.
By their numbers in this assay, from the lowest: compound 2; then compound 3; then compound 1.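

Within this assay, trimming the group on this oxygen does not steadily lower the number: a number 23 percentage points higher from compound 2 to compound 3 (beyond the scatter) on going from ethyl to methyl, whereas the change from cyclohexyl to methyl gives a number 13 percentage points lower from compound 1 to compound 3 (beyond the scatter) overall. The three groups therefore do not fall in order of chain length or bulk, since methyl in compound 3 ranks above ethyl in compound 2 yet under cyclohexyl in compound 1. Nothing measured here explains this reversal.

From the compounds shown here alone, whether ethyl is a lone low point stays open. An isopropyl, a propyl chain or a cyclopentyl ring at this place could show how the number moves among these groups.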